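The compounds below may be only part of what the source reports. "The series", "measured", "known", "first", "only" and "open" are said of these compounds alone.

Compound 1 `COc1ccc(-c2cc(/C=C/C(=O)c3ccc(N)cc3)[nH]n2)cc1`: 10600 nM
Compound 2 `COc1ccc(-c2cc(/C=C/C(=O)c3ccc(N)cc3)[nH]n2)cc1OC`: 3290 nM
Compound 3 `COc1cc(C(=O)/C=C/c2cc(-c3cc(OC)c(OC)c(OC)c3)n[nH]2)cc(OC)c1OC`: 3010 nM

All three were tested in a functional assay on ACHN cells (Homo sapiens) for inhibition, read by sulforhodamine B assay, with a stated time of 48 h; on this read-out lower numbers stand for stronger inhibition of growth and higher numbers for weaker inhibition of growth. Compound 2 and compound 3 give numbers within the usual scatter of each other, while compound 1 stands clearly apart from both. The structural step from compound 2 to compound 1 is hydrogen in place of methoxy on an aromatic carbon. The difference between the cores of compound 2 and compound 3 is not broken down here.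

Compound 4 `COc1ccc(-c2cc(/C=C/C(=O)c3cc(OC)c(OC)c(OC)c3)[nH]n2)cc1OC` has not yet been measured in this assay. It differs from compound 3 by hydrogen in place of methoxy on an aromatic carbon. Among the measured compounds shown here, this is the same kind of change as the one from compound 2 to compound 1, though not the same: here the place is also meta to a methoxy group. Because that earlier change made a 3.2-fold higher number from compound 2 to compound 1 (0.51 log units; beyond the scatter), a step of similar size is expected here, estimated as a 2.7-fold higher number from compound 3 to compound 4 (0.42 log units; beyond the scatter), with some caution since the surroundings of the place are not identical. Compound 4 is therefore expected to give about 8000 nM in this assay, most likely between 3000 nM and 20000 nM.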

Compound 4, concentration for total growth inhibition: 2820 nM
Estimate against measurement, compound 4: 2.8-fold (0.45 log units) above; the whole stated range lies above it.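

Removing this methoxy group in this assay gives a 1.1-fold lower number from compound 3 to compound 4 (0.03 log units; within the scatter), so the size of the step seen on the first core does not carry over to the second, and the two steps clearly differ: the same change on two cores in this assay, a 3.2-fold higher number (0.51 log units; beyond the scatter) from compound 2 to compound 1 and a 1.1-fold lower number (0.03 log units; within the scatter) from compound 3 to compound 4, 3.4-fold (0.54 log units) apart, beyond the scatter of two such steps. The same swap of methoxy for hydrogen can therefore matter on one core and make no difference that can be told from scatter on another, so a step read on one core is a poor guide to the size of the step on the other. Among the compounds shown here, with only two pairs of compounds, this does not show which part of the cores sets the difference, nor how the change would behave on any further core.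

The compounds shown leave open what a hydroxyl group or a chlorine atom would do at this place on either core. They also leave open whether the step would stay this small or grow on a core carrying a carboxylic acid where compound 1 has its amine.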